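A few compounds are considered here, and "the series" means these few. Any claim that something is new, unique, unknown or untested is made for them only; others in the source may bear on it.

Measured compounds: compound 1 `CC(C)(C)c1ccc(C(=O)N2CCC3(CC2)C(=O)N(CC(=O)NCCO)CN3c2ccccc2)cc1` gives 1000 nM in an assay on HEK293 cells for displacement of a labelled ligand from NPC1-like intracellular cholesterol transporter 1 (Homo sapiens); a lower number here means a stronger inhibitor, a higher number a weaker inhibitor; compound 2 `CC(C)(C)c1ccc(C(=O)N2CCC3(CC2)C(=O)N(CC(=O)N2CCCC(O)C2)CN3c2ccccc2)cc1` gives 12200 nM in this assay.

Of these two numbers, compound 2 has the higher one: the step of a 12-fold higher number from compound 1 to compound 2 (1.09 log units; beyond the scatter) is large. Compound 3 `CC(C)(C)c1ccc(C(=O)N2CCC3(CC2)C(=O)N(CC(=O)N2CCCCC2CO)CN3c2ccccc2)cc1` differs from compound 2 in one place, (2-(hydroxymethyl)piperidin-1-yl in place of 3-hydroxypiperidin-1-yl on a carbonyl carbon). Among the compounds with values here, no measured step swaps one hydroxylated piperidine ring for another, so the step from compound 1 to compound 2 gives only a loose reference. With both groups carrying the same counted donor and acceptor, no step beyond the scatter is expected in this assay. Compound 3 is therefore estimated at 10000 nM, in the range 3000 nM to 40000 nM, meaning an expected step of a 1.2-fold lower number from compound 2 to compound 3 (0.09 log units; within the scatter).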

Compound 3, half-maximal inhibitory concentration: 11800 nM
Compound 3: the middle estimate sits 1.2-fold (0.07 log units) below what was measured; measured number inside the range.
By their numbers in this assay, from the lowest: compound 1; then compounds 3 and 2 (each within the scatter of the next).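

In this assay the change to 2-(hydroxymethyl)piperidin-1-yl from 3-hydroxypiperidin-1-yl gives a 1.0-fold lower number from compound 2 to compound 3 (0.01 log units; within the scatter) and so leaves these two hydroxylated piperidine rings indistinguishable on this carbonyl carbon. The large gap to (2-hydroxyethyl)amino also appears with this second ring, as a 12-fold higher number from compound 1 to compound 3 (1.07 log units; beyond the scatter) shows, so it is not peculiar to 3-hydroxypiperidin-1-yl. Nothing available explains this gap.

Still open, going by these compounds, is whether plain piperidin-1-yl, with no hydroxyl, matches these rings, and whether a longer chain such as (3-hydroxypropyl)amino behaves like compound 1.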